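This account rests on a few compounds, and the source may have more. Where it says the series, first, only, none or still open, it means among the compounds named here.

In a functional assay on HCT-116 cells (Homo sapiens) for inhibition, read by sulforhodamine B assay, with a stated time of 48 h, tested at 50 uM (a lower number here means less inhibition of growth, a higher number more inhibition of growth at the concentration tested), compound 1 (`COc1cc2c(cc1CC=C(C)C)C(=O)C[C@@H](c1ccc(Oc3ccc(F)cc3)cc1)O2`) gives 29% and sits level with compound 3 (`COc1ccc([C@@H]2C/C(=N/OCc3cn(-c4cc(OC)c(OC)c(OC)c4)nn3)c3cc(CC=C(C)C)c(OC)cc3O2)cc1`), which gives 29% as well. These two share the lowest reading of the three measured compounds. Compound 2 (`COc1cc2c(cc1CC1OC1(C)C)C(=O)C[C@@H](c1ccc(O)cc1)O2`) gives 97% on the same read-out, a wide gap to these two.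

Compound 4 (`C#CCOc1ccc([C@@H]2CC(=O)c3cc(CC=C(C)C)c(OC)cc3O2)cc1`) keeps the core of compound 1 and changes one group, with propargyl in place of 4-fluorophenyl on an oxygen on an aromatic ring. Going by the values given here, no pair of measured compounds isolates this change, so the evidence for any forecast is thin. Compound 2 has no 4-fluorophenyl and reads 97% but also differs elsewhere, while compound 3 has none either and reads 29% in the same test.

In this assay a small rise is therefore expected, near the edge of the usual scatter, with the estimated step of a number 11 percentage points higher from compound 1 to compound 4 (beyond the scatter) as the working figure. For compound 4 the estimated value is 40% with an expected range from 15% to 70% at the tested concentration.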

Compound 4, percent growth inhibition at one concentration: 75%
Compound 4: the middle estimate sits 35 percentage points below what was measured; the whole stated range lies below it.
By their numbers in this assay, from the lowest: compounds 1 and 3 (each within the scatter of the next); then compound 4; then compound 2.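

In this assay, exchanging 4-fluorophenoxy for propargyloxy on the shared core gives a large step, a number 46 percentage points higher from compound 1 to compound 4 (beyond the scatter). Going by these compounds alone, this is the first direct reading of this position, and it shows that the group on this oxygen strongly affects growth inhibition: the ring-bearing group of 7 heavy atoms gives way to a ring-free group of 3 heavy atoms, and the reading rises well beyond the scatter. No measurement available here explains why the change has this effect.

The compounds shown do not separate the loss of the aromatic ring, the loss of fluorine and the arrival of the triple bond, which a plain phenyl or a propyl group on the same oxygen could help to pull apart. A reading at one concentration also leaves open how compound 1 and compound 4 would compare across a range of doses.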